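Working notes: cyclopropyl in place of propyl

The compounds below may be only part of what the source reports. "The series", "measured", "known", "first", "only" and "open" are said of these compounds alone.

Values measured in a functional assay (aorta) with Oryctolagus cuniculus as the target; a lower number here means tighter binding, a higher number weaker binding

compound 1 `CCCCc1nc2c(C)cccc2n1Cc1cc(Cl)c(O)c(Cl)c1` gives 20 nM
compound 2 `CCCCc1nc2cccnc2n1Cc1cc(Cl)c(O)c(Cl)c1` gives 63.1 nM
compound 3 `CCCc1nc2cccnc2n1Cc1cc(Cl)c(O)c(Cl)c1` gives 31.6 nM

Compound 3 stands at 31.6 nM and lies within the scatter of both compound 1 and compound 2, so its place among the three numbers carries little weight. The next structure is compound 4 `Oc1c(Cl)cc(Cn2c(C3CC3)nc3cccnc32)cc1Cl`, with cyclopropyl in place of propyl on an aromatic carbon. Among the measured compounds shown here, one measured step bears on this substituent, a 2.0-fold lower number from compound 2 to compound 3 (0.30 log units; within the scatter), and it stays within the scatter. For the measured compounds named here, no measured step involves compound 1, and no measured compound carries a ring at this place, so the evidence is indirect. In this assay no change beyond the scatter is therefore expected, with at most a slight drift toward a higher number. The estimated change is a 1.3-fold higher number from compound 3 to compound 4 (0.10 log units; within the scatter). For compound 4 the estimated value is 40 nM, with an expected range from 13 nM to 125 nM.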

Compound 4, dissociation constant: 20 nM
Compound 4: middle estimate off by 2.0-fold (0.30 log units), on the high side; the range from low to high includes it.
By their numbers in this assay, from the lowest: compounds 1, 4, 3 and 2 (each within the scatter of the next, the first and the last beyond it).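

In this assay, cyclopropyl in place of propyl on the aromatic carbon between two ring nitrogen atoms gives a 1.6-fold lower number from compound 3 to compound 4 (0.20 log units; within the scatter), so a three-membered non-aromatic ring of carbon only is tolerated here without a change that stands clear of the scatter. Cyclopropyl in place of butyl at the same place gives a 3.2-fold lower number from compound 2 to compound 4 (0.50 log units; beyond the scatter), the first step at this position to lie beyond the scatter, though only a modest one. Nothing measured accounts for either step.

Propyl lies within the scatter of both butyl and cyclopropyl, so the shown compounds do not separate the effect of the ring from that of the shorter group. As far as these compounds go, how an ethyl chain, a cyclobutyl ring or an amine would read at this place remains open.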